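Clearance limits and a reshaped side chain

The source may report more compounds than this note shows. Statements on the series, on what has been measured and on what is new or still open speak of the compounds shown alone.

Values in an ADME assay on microsomes from liver (Homo sapiens) for metabolic stability, read by LC-MS, tested at 1 uM (on this read-out lower numbers stand for slow clearance and higher numbers for fast clearance), each of them a limit:
- compound 1 (`NCCCOc1ccc([C@H]2CC[C@]3(CC2)OOC2(O3)C3CC4CC(C3)CC2C4)cc1`) gives < 7 mL.min-1.g-1 as a limit
- compound 2 (`NCCOc1ccc([C@H]2CC[C@]3(CC2)OOC2(O3)C3CC4CC(C3)CC2C4)cc1`) gives < 7 mL.min-1.g-1 as a limit
- compound 3 (`c1cc([C@H]2CC[C@]3(CC2)OOC2(O3)C3CC4CC(C3)CC2C4)ccc1OCCOC1CCNCC1`) gives < 7 mL.min-1.g-1 as a limit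

Compound 3 stands at < 7 mL.min-1.g-1 in this assay and this is a limit, not a number. It has no rank among the three compounds, which all share one reading (the limit of < 7 mL.min-1.g-1 in this assay, at which 3 of the 3 values shown sit).

Compound 4 (`CC(C)(O)CN1CCC(Oc2ccc([C@H]3CC[C@]4(CC3)OOC3(O4)C4CC5CC(C4)CC3C5)cc2)CC1`) differs from compound 3 at one place (1-(2-hydroxy-2-methylpropyl)piperidin-4-yl in place of 2-((piperidin-4-yl)oxy)ethyl on an oxygen on an aromatic ring). In words, 1-(2-hydroxy-2-methylpropyl)piperidin-4-yl sits in place of 2-((piperidin-4-yl)oxy)ethyl on an oxygen on an aromatic ring.

Among the compounds with values here, three measured steps concern this side chain (a step that the two limits leave unreadable from compound 1 to compound 2; a step that the two limits leave unreadable from compound 1 to compound 3; a step that the two limits leave unreadable from compound 2 to compound 3). None has a readable size, and none gives a direction. No step beyond the scatter is therefore expected in this assay. The expected change is a step that the limit leaves unreadable from compound 3 to compound 4 and no more. The estimated value for compound 4 is 6 mL.min-1.g-1 and the expected range runs from 3 mL.min-1.g-1 to 14 mL.min-1.g-1 in this estimate.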

Compound 4, intrinsic clearance in microsomes: 18 mL.min-1.g-1
Estimate against measurement, compound 4: 3.0-fold (0.48 log units) below; the measured number lies above the stated range.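

On an oxygen on an aromatic ring, 1-(2-hydroxy-2-methylpropyl)piperidin-4-yl gives a clear rise in this assay, with an at least 2.5-fold higher number from compound 3 to compound 4 (0.41 log units; beyond the scatter), an at least 2.5-fold higher number from compound 2 to compound 4 (0.41 log units; beyond the scatter) and an at least 2.5-fold higher number from compound 1 to compound 4 (0.41 log units; beyond the scatter). Within the data shown here, the steps among compound 1, compound 2 and compound 3 cannot be read, so this group is the first change at this position to give a step with a direction. Compound 4 alone stands clear of the reading shared by the others: the limit of < 7 mL.min-1.g-1 in this assay, at which 3 of the 4 values shown sit.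

The compounds shown do not separate the parts of this change, as compound 4 differs from compound 3 both in the link from the oxygen to the piperidine and in the 2-hydroxy-2-methylpropyl group on its nitrogen. As far as these compounds go, it remains open whether an unsubstituted piperidin-4-yl or a 1-methylpiperidin-4-yl on that oxygen would read like compound 3 or like compound 4.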